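Benzamido in Place of Methyl: Estimating Growth Inhibition

This account rests on a few compounds, and the source may have more. Where it says the series, first, only, none or still open, it means among the compounds named here.

Measured compounds:
compound 1, `CC(=O)Nc1ccc(CN2CCC=C(CCC(=O)NO)C2=O)cc1`: "not determined" (no result reported)
compound 2, `O=C(CCC1=CCCN(Cc2ccc([N+](=O)[O-])cc2)C1=O)NO`: 1110 nM
compound 3, `Cc1ccc(CN2CCC=C(CCC(=O)NO)C2=O)cc1`: "not determined" (no result reported)

Compound 3 stands without a number: of the three compounds, only compound 2 has one, and compound 1 is a further entry without a single number. In a functional assay on NUGC-3 cells (Homo sapiens) for inhibition, read by sulforhodamine B assay (on this read-out lower numbers stand for stronger inhibition of growth and higher numbers for weaker inhibition of growth), compound 2 gives 1110 nM. Compound 4, `O=C(CCC1=CCCN(Cc2ccc(NC(=O)c3ccccc3)cc2)C1=O)NO`, differs from compound 3 by benzamido in place of methyl on an aromatic carbon. Among the measured compounds shown here, no step between measured compounds is available, so the size and direction of the change can only be guessed; the benzamido group is estimated to leave growth inhibition within the scatter of what compound 2 shows. Compound 4 is therefore expected to give about 900 nM, with a range from 250 nM to 3500 nM.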

Compound 4, concentration for 50% growth inhibition: > 10000 nM
Compound 4 gave a limit, no number; the forecaster's own chance of this, stated with the estimate: 10%; at least 11-fold (1.04 log units) between middle value and limit.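

In this assay compound 4 gives > 10000 nM, which is a limit and not a number. Even so, the change of benzamido for nitro on this aromatic carbon, para to a large group, gives an at least 9.0-fold higher number from compound 2 to compound 4 (0.95 log units; beyond the scatter), so this position does not tolerate every group alike. Among the compounds shown here, it is the first readable sign that the group here can shift growth inhibition.

Steps involving compound 1 or compound 3 cannot be read, so the benzamido ring and its amide cannot be separated. Going by these compounds, how a simple amine or a carboxylic acid on this carbon would behave remains open.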